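Replacing 4-methylphenyl with 5-chlorothiophen-2-yl on a sulfonyl sulfur

The source may hold more compounds than are shown below. What is called first, only, known or untested is meant among the compounds shown, and "the series" means these compounds.

Three sulfonamides have been tested in an ADME assay on L6 cells (Rattus norvegicus) for cytotoxicity; a lower number here means a stronger inhibitor, a higher number a weaker inhibitor. Compound 1 (`O=[N+]([O-])c1ncn(CCCNS(=O)(=O)c2ccc(C(F)(F)F)cc2)n1`) gives 235000 nM, and compound 3 (`O=[N+]([O-])c1ncn(CCCCNS(=O)(=O)c2ccc(OC(F)(F)F)cc2)n1`) gives 112000 nM. Compound 2 (`Cc1ccc(S(=O)(=O)NCCCn2cnc([N+](=O)[O-])n2)cc1`) gives > 307000 nM, which is a limit of the assay and not a number.

Compound 4 (`O=[N+]([O-])c1ncn(CCCNS(=O)(=O)c2ccc(Cl)s2)n1`) has not yet been measured. It differs from compound 2 in one place: 5-chlorothiophen-2-yl in place of 4-methylphenyl on a sulfonyl sulfur. In short, 5-chlorothiophen-2-yl stands in place of 4-methylphenyl on a sulfonyl sulfur.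

Within the data shown here, only one measured step touches this part of the molecule, with methyl in place of trifluoromethyl on an aromatic carbon: an at least 1.3-fold higher number from compound 1 to compound 2 (0.11 log units; that floor lies within the scatter). That step is a floor within the scatter, so it sets no size for a swap of the whole ring. The nearest true numbers are compound 1 at 235000 nM and compound 3 at 112000 nM, so compound 4 is expected to land in their region. The estimated change, towards a lower number, is an at least 1.7-fold lower number from compound 2 to compound 4 (0.23 log units; that floor lies within the scatter). For compound 4 the estimate is 180000 nM, with an expected range from 70000 nM to 350000 nM.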

Compound 4, half-maximal inhibitory concentration: 244000 nM
The estimate for compound 4 lay 1.4-fold (0.13 log units) below the measured number; low and high end bracket the measured number.
By their numbers in this assay, from the lowest: compound 3; then compounds 1 and 4 (each within the scatter of the next). At a limit, above all of these: compound 2.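

In this assay compound 4 gives 244000 nM as a true number for a five-membered aromatic ring on the sulfonyl sulfur, and this value lies within the scatter of the value for compound 1. Compound 2 gives > 307000 nM as a limit of the assay and not a number. Going by these compounds, the swap of 4-methylphenyl for 5-chlorothiophen-2-yl reads as an at least 1.2-fold lower number from compound 2 to compound 4 (0.09 log units; that floor lies within the scatter) and so shows no change beyond the scatter, and its true size stays open because one end of the step is only a limit: the limit of > 307000 nM in this assay, at which 1 of the 4 values shown sits.

The compounds shown leave open how much of the number for compound 4 belongs to the ring and how much to the chlorine on it. Also open, on these data alone, is how an amine or a carboxylic acid in place of that chlorine would read in this assay against compound 4.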